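The source may hold more compounds than are shown below. What is called first, only, known or untested is meant among the compounds shown, and "the series" means these compounds.

Working notes on the series. Two compounds have numbers in an ADME assay on MT4 cells (Homo sapiens) for cytotoxicity, read by MTT assay, with a stated time of 5 days; on this read-out higher numbers stand for lower toxicity in this test and lower numbers for higher toxicity in this test. Compound 1 `O=[N+]([O-])c1ccc(-c2nnc(-c3cccnc3)n2Nc2nc3ccc(Br)cc3s2)cc1` gives 13.2 ug/mL in this assay. Within the data shown here, compound 2 `Fc1ccc2nc(Nn3c(-c4ccc(Cl)cc4)nnc3-c3cccnc3)sc2c1` gives 92.9 ug/mL in this assay, the higher of the two numbers, and the gap to compound 1 lies beyond the usual scatter; the two compounds differ in more than one place, so no single step is set out between them. Compound 3 `Clc1ccc(-c2nnc(-c3cccnc3)n2Nc2nc3ccc(Br)cc3s2)cc1` has not been measured in this assay. It differs from compound 2 by bromo in place of fluoro on an aromatic carbon. Among the measured compounds shown here, no measured pair shows this step alone. Compound 1 also carries bromo at that position and gives the lower number, but its other ring differs too, so the estimate for compound 3 is set between the two measured values and is expected to be 40 ug/mL with a range of 15 ug/mL to 110 ug/mL. The expected step is a 2.3-fold lower number from compound 2 to compound 3 (0.37 log units; beyond the scatter), a move toward a lower number that may not exceed the scatter.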

Compound 3, half-maximal cytotoxic concentration: 29.6 ug/mL
Compound 3: middle estimate off by 1.4-fold (0.13 log units), on the high side, and the stated range covers the measured number.
By their numbers in this assay, from the lowest: compound 1; then compound 3; then compound 2.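

In this assay the change of bromo in place of fluoro on an aromatic carbon of the fused system can now be read alone, as a 3.1-fold lower number from compound 2 to compound 3 (0.50 log units; beyond the scatter), and with bromo held fixed, chloro in place of nitro on an aromatic carbon gives a 2.2-fold higher number from compound 1 to compound 3 (0.35 log units; beyond the scatter) on the same read-out. Compound 3 thus links compound 1 and compound 2 through two one-place steps, both beyond the scatter, so the gap between those two no longer rests on a comparison of compounds differing in more than one place. No measurement at hand gives a reason for either step.

On these data alone, whether bromo in place of fluoro keeps this size with nitro in place of chloro stays open. As far as these compounds go, how an amine or a methoxy group would read at either aromatic carbon is also open.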